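Swapping the Aryl Group: From Compound 3 to Compound 4

The compounds below may be only part of what the source reports. "The series", "measured", "known", "first", "only" and "open" are said of these compounds alone.

Values in a functional assay on Jurkat cells for inhibition of nuclear factor NF-kappa-B complex (Homo sapiens); a higher number here means a weaker inhibitor, a lower number a stronger inhibitor:
Compound 1, `CCOC(=O)c1cnc(-c2ccccc2)nc1NN1C(=O)C=C(C)C1=O`: 100 nM
Compound 2, `CCOC(=O)c1cnc(-c2cccs2)nc1NN1C(=O)C=C(C)C1=O`: 20 nM
Compound 3, `CCOC(=O)c1cnc(-c2csc(C)n2)nc1NN1C(=O)C=C(C)C1=O`: 8000 nM

Compound 3 gives the highest number of the three, with an 80-fold higher number from compound 1 to compound 3 (1.90 log units; beyond the scatter) and a 400-fold higher number from compound 2 to compound 3 (2.60 log units; beyond the scatter). The unmeasured compound 4 is `CCOC(=O)c1cnc(-c2ccc(OC)cc2)nc1NN1C(=O)C=C(C)C1=O`, and it differs from compound 3 as follows: 4-methoxyphenyl in place of 2-methyl-1,3-thiazol-4-yl on an aromatic carbon. The step that bears on this is the one in the opposite direction, namely an 80-fold higher number from compound 1 to compound 3 (1.90 log units; beyond the scatter), which was large. Compound 4 carries a 4-methoxyphenyl group rather than the plain phenyl of compound 1, so it does not simply retrace that step, but a large drop in the number is expected in this assay, roughly a 53-fold lower number from compound 3 to compound 4 (1.73 log units; beyond the scatter). Compound 4 is therefore estimated at 150 nM, within a range from 30 nM to 800 nM.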

Compound 4, half-maximal inhibitory concentration: 900 nM
Compound 4: middle estimate off by 6.0-fold (0.78 log units), on the low side; measured number outside the range, above it.
By their numbers in this assay, from the lowest: compound 2; then compound 1; then compound 4; then compound 3.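

In this assay, methoxy on the phenyl group of compound 1 does not leave the number unchanged at this position, giving a 9.0-fold higher number from compound 1 to compound 4 (0.95 log units; beyond the scatter). The 4-methoxyphenyl group recovers only part of the ground lost with the 2-methyl-1,3-thiazol-4-yl group, with an 8.9-fold lower number from compound 3 to compound 4 (0.95 log units; beyond the scatter), and it remains far from thiophen-2-yl, with a 45-fold higher number from compound 2 to compound 4 (1.65 log units; beyond the scatter). Nothing available explains these differences.

As far as these compounds go, whether the rise from compound 1 is specific to methoxy remains open, as a 4-fluorophenyl or 4-methylphenyl group could show. The compounds also leave open how much of the high number of compound 3 depends on its methyl group.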